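The source may hold more compounds than are shown below. What is called first, only, known or untested is meant among the compounds shown, and "the series" means these compounds.

In a functional assay on A-375 cells (Homo sapiens) for antiproliferative activity (a lower number here means a stronger inhibitor, a higher number a weaker inhibitor), compound 3 `O=C(Nc1ccc(-c2ccncc2)cc1)C1CCCN(Cc2ccc(F)c(F)c2)C1` gives 600 nM. Compound 1 `O=C(Nc1ccc(-c2cscn2)cc1)C1CCCN(Cc2cccc(OC(F)(F)F)c2)C1` reaches only the limit of > 20000 nM, which is not a number. Compound 2 `O=C(Nc1ccc(-c2cscn2)cc1)C1CCCN(Cc2ccc3cn[nH]c3c2)C1` likewise sits at the limit of > 20000 nM. Among the three values shown, compound 3 therefore holds the only number, the other two resting at the limit of > 20000 nM in this assay, at which 2 of the 3 values shown sit. Compound 4 `O=C(Nc1ccc(-c2cccs2)cc1)C1CCCN(Cc2ccc(F)c(F)c2)C1` differs from compound 3 in one place: thiophen-2-yl in place of pyridin-4-yl on an aromatic carbon. Going by the values given here, no measured pair shares this change, so its size is open. In this assay the expected step is a 1.5-fold higher number from compound 3 to compound 4 (0.18 log units; within the scatter), which stays within the usual scatter. The estimate for compound 4 is 900 nM, spanning 300 nM to 3000 nM.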

Compound 4, half-maximal inhibitory concentration: 390 nM
The estimate for compound 4 lay 2.3-fold (0.36 log units) above the measured number, and the stated range covers the measured number.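

In this assay the step is a 1.5-fold lower number from compound 3 to compound 4 (0.19 log units; within the scatter), with thiophen-2-yl in place of pyridin-4-yl on an aromatic carbon, para to a large group. This is the only pair shown that differs in one place, and it shows that a five-membered aromatic ring with sulfur can stand here for a six-membered aromatic ring with nitrogen without a change beyond the scatter. Nothing at hand gives a cause for this step. Going by these compounds, whether a phenyl ring or a morpholine in this place would keep such a number stays open. Compounds 1 and 2 differ from compounds 3 and 4 in more than one place, so those comparisons cannot be read as steps.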